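The compounds below may be only part of what the source reports. "The series", "measured", "known", "first", "only" and "open" are said of these compounds alone.

Working notes on the sulfonamide-acetamide series.

Compound 2 `COc1cccc(NC(=O)CN(c2cc(Cl)ccc2OC)S(=O)(=O)c2ccccc2)c1` is the reference for this step. In a functional assay on SH-SY5Y cells (Homo sapiens), read by MTT assay, with a stated time of 24 h (on this read-out higher numbers stand for an effect only at larger amounts of compound and lower numbers for an effect already at smaller amounts), compound 2 gives 17600 nM, which is the higher of the two numbers recorded so far, though only narrowly; its nearest neighbour is compound 1 `COc1ccc(Cl)cc1N(CC(=O)N1CCCCC1)S(=O)(=O)c1ccccc1`, for which 14500 nM was found in this assay. Going by the values given here, the one measured step between them, a 1.2-fold higher number from compound 1 to compound 2 (0.08 log units; within the scatter), exchanges the piperidin-1-yl on the carbonyl carbon for (3-methoxyphenyl)amino and is within the scatter.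

Compound 3 `COc1ccc(Cl)cc1N(CC(=O)NC1CCCCC1)S(=O)(=O)c1ccccc1` has not yet been measured in this assay. It differs from compound 2 as follows: cyclohexyl in place of 3-methoxyphenyl on an amide-type nitrogen. Among the compounds with values here, no measured step touches exactly this exchange; the only step that bears on it is the one from compound 1 to compound 2, which was within the scatter, and compound 1 itself carries a saturated ring at the carbonyl carbon. On that basis no step beyond the scatter is expected for compound 3: the expected step is a 1.2-fold lower number from compound 2 to compound 3 (0.07 log units; within the scatter). For compound 3 the estimate in this assay is therefore 15000 nM, with an expected range from 6000 nM to 40000 nM.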

Compound 3, half-maximal effective concentration: 17600 nM
Compound 3: the middle estimate sits 1.2-fold (0.07 log units) below what was measured; measured number inside the range.
By their numbers in this assay, from the lowest: compounds 1, 2 and 3 (each within the scatter of the next).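

In this assay the exchange on the amide-type nitrogen (with no change at the digits printed from compound 2 to compound 3 (within the scatter)) shows that this position does not separate a 3-methoxyphenyl from a cyclohexyl, so a six-membered aromatic ring of carbon only carrying a methoxy group and a six-membered non-aromatic ring of carbon only read alike here. The second new comparison, cyclohexylamino in place of piperidin-1-yl on the carbonyl carbon (with a 1.2-fold higher number from compound 1 to compound 3 (0.08 log units; within the scatter)), adds that two groups with saturated rings also read alike, although only cyclohexylamino keeps the amide hydrogen. All three groups on the carbonyl carbon now lie within the scatter of one another, and none of the data shown bears on why this is so.

Going by these compounds, it remains open whether a group of another kind at this place, such as a carboxylic acid, a basic amine or a longer alkyl chain on the amide-type nitrogen, would move the number beyond the scatter. The compounds shown also leave open what changes on the shared core would do, for instance a fluoro in place of the chloro, since all three carry the same core.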